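The source may report more compounds than this note shows. Statements on the series, on what has been measured and on what is new or still open speak of the compounds shown alone.

Working notes on the series. Compound 1 `CC(C)c1ccccc1-c1cc2cc(CCC(=O)O)ccc2[nH]1` gives only a limit in a functional assay on CHO cells for agonist activity at Free fatty acid receptor 1 (Homo sapiens), read by a luciferase reporter, with a stated time of 24 h (a higher number here means that more compound is needed for the effect, a lower number that less compound is needed), namely > 25 nM. Compound 2 `CCc1ccccc1-c1cc2cc(CCC(=O)O)ccc2[nH]1` gives 1800 nM in this assay. Between them lies a step that the limit leaves unreadable from compound 1 to compound 2. Compound 3 `Cc1ncccc1-c1cc2cc(CCC(=O)O)ccc2[nH]1` likewise gives only a limit in this assay, > 25 nM. Among the measured compounds shown here, compound 3 thus stands at the limit of > 25 nM in this assay, at which 2 of the 3 values shown sit, and the one further value shown for the series is itself a limit. Compound 4 `O=C(O)CCc1ccc2[nH]c(-c3ccccc3Cl)cc2c1` differs from compound 3 by 2-chlorophenyl in place of 2-methylpyridin-3-yl on an aromatic carbon. No measured step bears on this change, and the one step shown for the series is unreadable, so the expected size of a step that the limit leaves unreadable from compound 3 to compound 4 cannot be anchored and rests only on the single number of the series, that of compound 2. Compound 4 is expected near 3000 nM, within 600 nM to 15000 nM.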

Compound 4, half-maximal effective concentration: 54.6 nM
For compound 4 the middle estimate is 55-fold (1.74 log units) above the measured one; the whole stated range lies above it.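

In this assay, among the compounds shown here, chloro in place of ethyl gives a 33-fold lower number from compound 2 to compound 4 (1.52 log units; beyond the scatter), the first readable step for a change on this aromatic ring. The steps to compound 4 from compound 1 and from compound 3 cannot be read, because each starts from a value that is a limit: the limit of > 25 nM in this assay, at which 2 of the 4 values shown sit.

The compounds shown do not separate the loss of the ring nitrogen from the entry of chloro in 2-chlorophenyl replacing 2-methylpyridin-3-yl. From the compounds shown here alone, whether a bromo, methoxy or trifluoromethyl group would match chloro here also remains open.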